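This account rests on a few compounds, and the source may have more. Where it says the series, first, only, none or still open, it means among the compounds named here.

Working notes on the series. The shared core of compound 1 `CO/N=C(\C)c1ccc(Sc2cc(F)cc(C3CCOCC3)c2)cc1` is carried unchanged into compound 2 `C/C(=N\OCCSc1nnc(C)s1)c1ccc(Sc2cc(F)cc(C3CCOCC3)c2)cc1` and compound 3 `CN(C)/C(=N\O)c1ccc(Sc2cc(F)cc(C3CCOCC3)c2)cc1`. In a functional assay (blood) for inhibition, with Homo sapiens as the target (on this read-out higher numbers stand for weaker inhibition and lower numbers for stronger inhibition), compound 1 gives 110 nM, the lowest number of the three; compound 2 gives 230 nM and compound 3 gives 280 nM. Both departures from compound 1 move the number upward: a 2.1-fold higher number from compound 1 to compound 2 (0.32 log units; beyond the scatter) and a 2.5-fold higher number from compound 1 to compound 3 (0.41 log units; beyond the scatter).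

Compound 4 `C/C(=N\OC(=O)C(C)(C)C)c1ccc(Sc2cc(F)cc(C3CCOCC3)c2)cc1` differs from compound 1 by (tert-butyl)carbonyl in place of methyl on an oxygen, the change sitting on an oxygen whose other neighbour is a double-bonded nitrogen. For the measured compounds named here, of the measured steps, the one from compound 1 to compound 2 is the closest guide, as it also enlarges the methoxy end of compound 1 and gave a modest rise; the step to compound 3 points the same way. Going by the values given here, no step reduces the number. On that basis a modest weakening of inhibition is expected in this assay, of about the size seen in compound 2: a 2.3-fold higher number from compound 1 to compound 4 (0.36 log units; beyond the scatter). The estimate for compound 4 in this assay is 250 nM, with a range of 110 nM to 600 nM.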

Compound 4, half-maximal inhibitory concentration: 40 nM
For compound 4 the middle estimate is 6.3-fold (0.80 log units) above the measured one; the whole stated range lies above it.
By their numbers in this assay, from the lowest: compound 4; then compound 1; then compounds 2 and 3 (each within the scatter of the next).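

In this assay, (tert-butyl)carbonyl in place of methyl on the oxygen whose other neighbour is a double-bonded nitrogen gives a 2.8-fold lower number from compound 1 to compound 4 (0.44 log units; beyond the scatter) and is the only departure from compound 1 shown that lowers the number. A larger group on this oxygen therefore does not by itself raise the number: (tert-butyl)carbonyl in place of 2-((5-methyl-1,3,4-thiadiazol-2-yl)sulfanyl)ethyl gives a 5.8-fold lower number from compound 2 to compound 4 (0.76 log units; beyond the scatter) on the same oxygen. The wider change at this end of the molecule gives a 7.0-fold lower number from compound 3 to compound 4 (0.85 log units; beyond the scatter) and places compound 4 below compound 3 as well.

Nothing available explains the direction of these steps. Going by these compounds, whether the lower number goes with the carbonyl or with the tert-butyl stays open, and acetyl or neopentyl on the same oxygen would separate the two.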